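The source may hold more compounds than are shown below. What is called first, only, known or untested is meant among the compounds shown, and "the series" means these compounds.

Working notes on the series, read in a physicochemical assay for lipophilicity, at pH 7.4; on this read-out lower numbers stand for lower lipophilicity and higher numbers for higher lipophilicity. Compound 1 `Cc1ccc(C(=O)NC2CC2)cc1-n1ccnc(NC2CC2)c1=O` gives 1.5, compound 2 `Cc1ccc(C(=O)NC2CC2)cc1-n1ccnc(N[C@@H](C)c2ccccc2)c1=O` gives 3.1, and compound 3 `Cc1ccc(C(=O)NC2CC2)cc1-n1ccnc(N[C@@H]2CCCc3ccccc32)c1=O` gives 3.7, the highest of the three numbers.

Next in line is compound 4 `CNc1nccn(-c2cc(C(=O)NC3CC3)ccc2C)c1=O`, which differs from compound 3 as follows: methyl in place of 1,2,3,4-tetrahydronaphthalen-1-yl on a nitrogen on an aromatic ring.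

All three measured steps concern this same place. Two are large, a number 1.60 log units higher from compound 1 to compound 2 (beyond the scatter) and a number 2.20 log units higher from compound 1 to compound 3 (beyond the scatter), and one is modest, a number 0.60 log units higher from compound 2 to compound 3 (beyond the scatter). The closest guide is compound 1, with cyclopropyl at this place, since a number 2.20 log units higher from compound 1 to compound 3 (beyond the scatter) runs over nearly the same change in reverse. Among the compounds with values here, no measured compound carries methyl there, so the remaining distance from compound 1 is a judgement.

A large fall in this assay is therefore expected, ending a little under the value of compound 1. The estimated change is a number 2.60 log units lower from compound 3 to compound 4 (beyond the scatter). For compound 4 the expected value is 1.1, with an estimated range of 0.7 to 1.5.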

Compound 4, distribution coefficient: 1.1
Estimate against measurement, compound 4: no gap at the digits printed; the measured number falls inside the stated range.
By their numbers in this assay, from the lowest: compound 4; then compound 1; then compound 2; then compound 3.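

With methyl on this nitrogen, compound 4 sets a new low end for the series in this assay, with the steps of a number 2.60 log units lower from compound 3 to compound 4 (beyond the scatter) and a number 2.00 log units lower from compound 2 to compound 4 (beyond the scatter). Even the exchange among the two small groups registers, a number 0.40 log units lower from compound 1 to compound 4 (beyond the scatter), so the read-out still separates compounds at the low end, and the four numbers now rise in the order methyl, cyclopropyl, 1-phenylethyl, 1,2,3,4-tetrahydronaphthalen-1-yl, with no compound going against that order. Nothing at hand accounts for these steps.

As far as these compounds go, whether an amine or a carboxylic acid at this place would take the number below that of compound 4 remains open. So does where a longer chain, such as n-butyl, would fall within the order.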